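The compounds below may be only part of what the source reports. "The series", "measured", "known", "first", "only" and "open" are said of these compounds alone.

Series notes. Compound 1 `O=C1CCCC2=C1C(c1ccc(F)cc1)C=C(c1ccccc1)N2` carries a 4-fluorophenyl group on one core; in an assay on isolated protein for inhibition of glucose-6-phosphatase catalytic subunit 1 (Homo sapiens), read by inositol phosphate accumulation, with a stated time of 30 min, tested at 100 uM (on this read-out higher numbers stand for more inhibition at the one concentration tested (going by the name of the read-out) and lower numbers for less inhibition), compound 1 gives 21.9%. Compound 3 `O=C1CCCC2=C1C(c1ccc(Cl)cc1)C=C(c1ccccc1)N2` is its chloro analogue, and in this assay compound 3 gives 8.21%. The change chloro in place of fluoro on an aromatic carbon therefore made a step of a number 13.7 percentage points lower from compound 1 to compound 3 (beyond the scatter).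

Compound 2 `CC1(C)CC(=O)c2c(-c3ccc(F)cc3)cc(-c3ccccc3)nc2C1` sits on a different core; how the two cores differ is not broken down here. In this assay compound 2 gives 11.1%, a number beyond the scatter below compound 1 and within the scatter of compound 3, so no order between compound 2 and compound 3 is claimed.

Compound 4 `CC1(C)CC(=O)c2c(-c3ccc(Cl)cc3)cc(-c3ccccc3)nc2C1` is the not yet measured chloro analogue of compound 2, made by the change (chloro in place of fluoro on an aromatic carbon). The place of this change reads the same, word for word, as in the pair of compound 1 and compound 3, so it is the same change, carried out on the second core. For the measured compounds named here, with only one measured instance of the change, on one core, the transfer to compound 2 is uncertain; the one data point points downward.

The step from compound 2 to compound 4 is expected to be a number 9.1 percentage points lower from compound 2 to compound 4 (within the scatter), because compound 1 to compound 3 showed a number 13.7 percentage points lower from compound 1 to compound 3 (beyond the scatter). For compound 4 in this assay the estimate is 2%, with a range expected from -10% to 15%.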

Compound 4, a percentage reported as inhibition, at one concentration (the size of the read-out at that concentration, not a potency): 11.3%
The estimate for compound 4 lay 9.3 percentage points below the measured number; the measured number falls inside the stated range.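

On the core of compound 2, the change from 4-fluorophenyl to 4-chlorophenyl gives a step of a number 0.2 percentage points higher from compound 2 to compound 4 (within the scatter) in this assay, so no effect of this change can be read on that core. Set beside the step on the core of compound 1, the two instances do not separate: the same change on two cores in this assay, a number 13.7 percentage points lower (beyond the scatter) from compound 1 to compound 3 and a number 0.2 percentage points higher (within the scatter) from compound 2 to compound 4, 13.9 percentage points apart, within the scatter of two such steps. The drop seen on the core of compound 1 therefore did not recur on the core of compound 2, yet the gap between the steps does not show that the outcome depends on the core, and with a single pair on each core, neither transfer of the change nor its failure to transfer is established.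

The compounds shown leave open whether a group other than fluoro or chloro at this place, such as methoxy, a nitrile or an amine, would give a number in this assay that stands clear of these on either core. They also leave open what replacing the unsubstituted phenyl group would do, and, with each compound read at one concentration only, how the compounds would rank in potency.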